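Notes on the aryl change from compound 1 to compound 4

A few compounds are considered here, and "the series" means these few. Any claim that something is new, unique, unknown or untested is made for them only; others in the source may bear on it.

Measured compounds:
Compound 1 `Cc1cc(C(=O)O)ccc1CN1CCC[C@H](O[C@H](CO)c2ccnc(Cl)c2)[C@@H]1c1ccccc1`: in an assay on isolated protein for activation of cGMP-dependent protein kinase 1 (Homo sapiens), read by ADP-Glo, with stated times of 30 min and 2 h (a lower number here means that less compound is needed, a higher number that more compound is needed for the effect), compound 1 gives only a limit, > 200000 nM.
Compound 2 `O=C(O)c1ccc(CN2CCC[C@H](O[C@H](CO)c3cc(Cl)cc(Cl)c3)[C@@H]2c2ccccc2)c([N+](=O)[O-])c1`: in this assay compound 2 gives 13000 nM.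
Compound 3 `O=C(O)c1ccc(CN2CCC[C@H](O[C@H](CO)c3cc(Cl)cc(Cl)c3)[C@@H]2c2ccccc2)cc1`: in this assay compound 3 gives 77000 nM.

Compound 1 stands at the limit of this assay, (the limit of > 200000 nM in this assay, at which 1 of the 3 values shown sits), so its true value is not known. Compound 4 `Cc1cc(C(=O)O)ccc1CN1CCC[C@H](O[C@H](CO)c2cc(F)cc(F)c2)[C@@H]1c1ccccc1` differs from compound 1 by 3,5-difluorophenyl in place of 2-chloropyridin-4-yl on a saturated chain carbon bound to an oxygen on a saturated carbon and a saturated chain carbon. Among the compounds with values here, the only measured step, a 5.9-fold higher number from compound 2 to compound 3 (0.77 log units; beyond the scatter), concerns a different position and does not bear on this change. Compounds 2 and 3 carry a 3,5-dichlorophenyl at the same place and give numbers rather than limits. Compound 4 is therefore expected to reach a measurable number, estimated at 100000 nM (range 30000 nM to 200000 nM). The expected step of an at least 2.0-fold lower number from compound 1 to compound 4 (0.30 log units; that floor lies within the scatter) rests on a limit and is uncertain.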

Compound 4, half-maximal effective concentration: > 200000 nM
Compound 4: a limit, no number (the forecaster's own chance of this, stated with the estimate: 35%); middle value at least 2.0-fold (0.30 log units) from the limit.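

Within the data shown here, compound 1 and compound 4 both stand at a limit, not a number, so no step between them can be read: the limit of > 200000 nM in this assay, at which 2 of the 4 values shown sit. The compounds shown leave open whether 3,5-difluorophenyl or 2-chloropyridin-4-yl gives the lower number.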